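Swapping a methyl for a hydroxy on the shared core

A few compounds are considered here, and "the series" means these few. Any claim that something is new, unique, unknown or untested is made for them only; others in the source may bear on it.

Measured so far:
- Compound 1, `Cc1nc(N)nc2c1c(-c1ccc3oc(N)nc3c1)nn2C(C)C`. In an ADME assay on microsomes from liver (Homo sapiens) for metabolic stability, read by LC-MS, with a stated time of 15 min, tested at 1 uM, in the presence of a further agent that is not named here (a higher number here means that more of the compound is left, a lower number that less of the compound is left), compound 1 gives > 95%, which is a limit of the assay rather than a number (the limit of > 95% in this assay, at which 1 of the 2 values shown sits).
- Compound 2, `CCc1nc(N)nc2c1c(-c1ccc3oc(N)nc3c1)nn2C(C)C`. In this assay compound 2 gives 93%.

Among the measured compounds shown here, compound 2 thus holds the only number given; the other value is a limit. For the measured compounds named here, the one measured step, a number at least 2 percentage points lower from compound 1 to compound 2 (that floor lies within the scatter), lies within the scatter.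

Compound 3, `CC(C)n1nc(-c2ccc3oc(N)nc3c2)c2c(CO)nc(N)nc21`, differs from compound 2 by hydroxy in place of methyl on a saturated chain carbon bound to an aromatic carbon. Going by the values given here, the only measured step touches the same saturated chain carbon, and it stayed within the scatter, so it offers little guidance on a hydroxy entering there. Compound 3 is expected to give about 85%, estimated to fall between 60% and 97%. The implied step, a number 8 percentage points lower from compound 2 to compound 3 (within the scatter), is expected to be small, possibly not beyond the scatter.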

Compound 3, percent of the compound remaining: > 95%
Compound 3 gave a limit, no number (the forecaster's own chance of this, stated with the estimate: 20%); at least 10 percentage points between middle value and limit.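

Placing a hydroxy on this saturated chain carbon gives a number at least 2 percentage points higher from compound 2 to compound 3 (that floor lies within the scatter), so the change shows no loss of compound in this assay, and no gain can be claimed either. The earlier compounds shown here showed only hydrogen and methyl at this carbon, whereas compound 3 shows that a group carrying oxygen can sit there while the read-out stays at its upper end. Compound 3 gives > 95%, which is a limit and not a number, and the read-out can separate little at this end of its range: the limit of > 95% in this assay, at which 2 of the 3 values shown sit.

The step from compound 1 to compound 3 cannot be read, as both values are limits. On these data alone, how an amine, a carboxylic acid or a longer chain at this carbon would fare in this assay remains open.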